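Difluorophenyl for dichlorophenyl on the carbonyl carbon

The compounds below may be only part of what the source reports. "The series", "measured", "known", "first", "only" and "open" are said of these compounds alone.

Compound 1 `COc1cc(-c2cc(/C=C/C(=O)c3ccc(Cl)c(Cl)c3)[nH]n2)cc(OC)c1OC` gives 68% in a functional assay on HOP-62 cells (Homo sapiens) for cytotoxicity, read by sulforhodamine B assay, with a stated time of 48 h, tested at 1 uM; on this read-out higher numbers stand for a weaker effect at the one concentration tested and lower numbers for a stronger effect. That is the lowest of the three numbers in hand, but the nearest neighbour, compound 3 `COc1cc(C(=O)/C=C/c2cc(-c3cc(OC)c(OC)c(OC)c3)n[nH]2)cc(OC)c1OC`, gives 78% in this assay, and that gap lies within the scatter, so the two cannot be ranked against each other. Compound 2 `COc1ccc(-c2cc(/C=C/C(=O)c3ccc(N)cc3)[nH]n2)cc1` gives 102% in this assay, a gap from compound 1 that is beyond the scatter. None of the three measured compounds differ from one another in a single place, so no step size is available from them.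

Compound 4 `COc1cc(-c2cc(/C=C/C(=O)c3ccc(F)c(F)c3)[nH]n2)cc(OC)c1OC` has not been measured. The change from compound 1 is 3,4-difluorophenyl in place of 3,4-dichlorophenyl on a carbonyl carbon. Going by the values given here, with no comparable step to lean on, and compound 3 showing that a different arrangement of the same methoxylated groups around the core yields 78%, no step beyond the scatter is expected here. The estimate for compound 4 in this assay is 76%, with a range from 58% to 94%. The expected step of a number 8 percentage points higher from compound 1 to compound 4 (within the scatter) is small, leaning if at all toward a weaker effect.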

Compound 4, a percentage reported as activity, at one concentration (the size of the read-out at that concentration, not a potency): 94%
Compound 4: middle estimate off by 18 percentage points, on the low side, within the range that was stated.
By their numbers in this assay, from the lowest: compounds 1 and 3 (each within the scatter of the next); then compounds 4 and 2 (each within the scatter of the next).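

In this assay, going by these compounds alone, putting 3,4-difluorophenyl in place of 3,4-dichlorophenyl on a carbonyl carbon gives a number 26 percentage points higher from compound 1 to compound 4 (beyond the scatter), the first single-place comparison and a modest step. It shows that this position does not tolerate every halogen exchange without a change in read-out: the effect at the one concentration tested is weaker with 3,4-difluorophenyl, even though the computed counts for the two groups differ only in chlorine giving way to fluorine. Nothing in hand bears on what lies behind this step.

Still open, going by these compounds, is whether a dibromophenyl or a dimethylphenyl group on the same carbonyl carbon would read like the 3,4-dichlorophenyl of compound 1 or like the 3,4-difluorophenyl of compound 4, which would show whether this step belongs to these two groups alone or to a wider trend at the position. Within the data shown here, it is equally open whether the same exchange keeps its size on the core of compound 2, since the one step available comes from a single core.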